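Replacing cyclohexylmethyl with oxan-4-yl in compound 2

The source may hold more compounds than are shown below. What is called first, only, known or untested is meant among the compounds shown, and "the series" means these compounds.

Measured in a physicochemical assay for lipophilicity, at pH 7.4; on this read-out lower numbers stand for lower lipophilicity and higher numbers for higher lipophilicity:
- compound 1 `Cc1cc(C(=O)NCc2ccccc2)nn1Cc1cc(Cl)ccc1OCc1ccccc1` gives > 3.7 (a limit)
- compound 2 `Cc1cc(NC(=O)CC2CCCCC2)nn1Cc1cc(Cl)ccc1OCc1ccccc1` gives 3.2

Compound 1 sits at the limit of > 3.7 in this assay, at which 1 of the 2 values shown sits, and that entry is only a limit. Among the compounds with values here, compound 2 therefore holds the only actual number in this assay, which is 3.2 on the scale so far. Compound 3 `Cc1cc(NC(=O)C2CCOCC2)nn1Cc1cc(Cl)ccc1OCc1ccccc1` carries the next change, (oxan-4-yl in place of cyclohexylmethyl on a carbonyl carbon), with oxan-4-yl in place of cyclohexylmethyl on a carbonyl carbon. Within the data shown here, the one measured step, a number at least 0.50 log units lower from compound 1 to compound 2 (beyond the scatter), concerns other groups and is only a loose guide to size. A fall beyond the scatter is expected here, as a number 1.10 log units lower from compound 2 to compound 3 (beyond the scatter), since the carbon-only ring leaves and a hydrogen-bond acceptor enters. For compound 3 the estimate is 2.1, with an expected range of 1.6 to 2.6 in this assay.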

Compound 3, distribution coefficient: > 3.7
Compound 3 was reported as a limit; the forecaster's own chance of this, stated with the estimate: 2%; at least 1.60 log units between middle value and limit.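

In this assay compound 3 gives > 3.7, which is a limit and not a number. On this carbonyl carbon, the change from cyclohexylmethyl to oxan-4-yl, which brings in a hydrogen-bond acceptor, gives a number at least 0.50 log units higher from compound 2 to compound 3 (beyond the scatter), while the step between compound 1 and compound 3 cannot be read, with a limit at each end. Compound 2 is now the only one with an actual number: the limit of > 3.7 in this assay, at which 2 of the 3 values shown sit.

From the compounds shown here alone, how far compound 3 lies past its limit stays open. Also open, going by these compounds, is how cyclohexyl or piperidin-4-yl, a ring amine, would read on the same carbonyl carbon.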